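The compounds below may be only part of what the source reports. "The series", "measured", "known", "first", "only" and "open" are said of these compounds alone.

In a functional assay on NCI-H23 cells (Homo sapiens) for inhibition, read by sulforhodamine B assay, with a stated time of 48 h (on this read-out lower numbers stand for stronger inhibition of growth and higher numbers for weaker inhibition of growth), compound 1 `Nc1cc(N)c2nc(-c3ccccc3)c(Oc3ccc(Cl)c(Cl)c3)nc2c1` gives 15500 nM, and compound 2 `Nc1cc(N)c2nc(-c3ccccc3)c(NCc3ccc(Cl)c(Cl)c3)nc2c1` gives 14100 nM. For compound 3 `COc1ccc(Sc2nc3cc(N)cc(N)c3nc2-c2ccccc2)cc1` this assay reports only a limit of < 100000 nM. Compound 3 thus stands at the limit (the limit of < 100000 nM in this assay, at which 1 of the 3 values shown sits), and the step from compound 1 to compound 3 is a step that the limit leaves unreadable from compound 1 to compound 3. Compound 4 `Nc1cc(N)c2nc(-c3ccccc3)c(Oc3ccc(F)cc3)nc2c1` differs from compound 3 by 4-fluorophenoxy in place of (4-methoxyphenyl)sulfanyl on an aromatic carbon. For the measured compounds named here, no measured step bears directly on this exchange; the single step touching compound 3 is unreadable, so neither size nor direction in this assay can be drawn from it. Compound 1, which also carries an oxygen-linked aromatic ring, gives 15500 nM, and compound 4 is expected near that figure. The step from compound 3 to compound 4 is therefore estimated as a step that the limit leaves unreadable from compound 3 to compound 4. Compound 4 is estimated at 20000 nM, within 5000 nM to 80000 nM.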

Compound 4, concentration for 50% growth inhibition: 20900 nM
Compound 4: the middle estimate sits 1.0-fold (0.02 log units) below what was measured; the range from low to high includes it.
By their numbers in this assay, from the lowest: compounds 2, 1 and 4 (each within the scatter of the next).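

Among the oxygen-linked compounds, 4-fluorophenyl and 3,4-dichlorophenyl on the oxygen are not told apart in this assay: the exchange is a 1.3-fold higher number from compound 1 to compound 4 (0.13 log units; within the scatter). The step from compound 3 to compound 4 cannot be read, because compound 3 stands at a limit: the limit of < 100000 nM in this assay, at which 1 of the 4 values shown sits.

Going by these compounds, what a sulfur link gives as a readable number therefore stays open. Also open, on these data alone, is how this assay responds when a carboxylic acid or an amine replaces the halogens on this aromatic ring, or when a longer chain replaces the ring altogether.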